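Naphthalen-2-yl to 3-Chlorophenyl: an Expected Step

A few compounds are considered here, and "the series" means these few. Any claim that something is new, unique, unknown or untested is made for them only; others in the source may bear on it.

Compound 3 `COc1ccc2nccc(C3CN(C4CCN(Cc5ccc6ccccc6c5)CC4)C(=O)O3)c2c1` was tested in an in vitro functional assay on RBL cells for antagonist activity at C-C chemokine receptor type 8 (Homo sapiens), read by FLIPR and calcium flux (on this read-out lower numbers stand for stronger inhibition and higher numbers for weaker inhibition), where compound 3 gives 1260 nM. That is the lower of the two numbers measured here, but compound 1 `COc1ccc2nccc(C3CN(CCCNCc4cc5ccccc5[nH]4)C(=O)O3)c2c1` sits within the scatter of it: in this assay compound 1 gives 1580 nM, so no order between the two can be claimed. Compound 2 `COc1ccc2nccc(C3CN(C4CCN(Cc5cc6ccccc6[nH]5)C4)C(=O)O3)c2c1` gives only a limit of the assay in this assay, namely < 50200 nM. This is the limit of < 50200 nM in this assay, at which 1 of the 3 values shown sits.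

Compound 4 `COc1ccc2nccc(C3CN(C4CCN(Cc5cccc(Cl)c5)CC4)C(=O)O3)c2c1` has not been measured. It differs from compound 3 in a single place: 3-chlorophenyl in place of naphthalen-2-yl on a saturated chain carbon bound to an amine nitrogen in a ring. Within the data shown here, no measured pair here shows this same change, so its size cannot be read from the data, and compound 2 lies too far from both to help. With the smaller aromatic group taking the place of the larger one, the expected step from compound 3 to compound 4 is a 2.0-fold higher number from compound 3 to compound 4 (0.30 log units; within the scatter), a mild weakening that could still fall inside the usual scatter. Compound 4 is therefore estimated at 2500 nM in this assay, with a range from 700 nM to 9000 nM.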

Compound 4, half-maximal inhibitory concentration: 6310 nM
The estimate for compound 4 lay 2.5-fold (0.40 log units) below the measured number, within the range that was stated.
By their numbers in this assay, from the lowest: compounds 3 and 1 (each within the scatter of the next); then compound 4.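

Among these compounds, this is the first step in the set where only one place changes, so the effect of this group can be read directly. In this assay the exchange of naphthalen-2-yl for 3-chlorophenyl, on a saturated chain carbon bound to an amine nitrogen in a ring, gives a 5.0-fold higher number from compound 3 to compound 4 (0.70 log units; beyond the scatter) and so shows that this position responds to the aromatic group it carries, which compound 1 and compound 3, being within the scatter of each other and differing in more than one place, could not show. Nothing measured here explains the size of this step.

The change removes one aromatic ring and adds a chlorine at once, and a plain phenyl group would be needed to separate the two. As far as these compounds go, how a methoxy group or an amine in place of the chlorine would read out also stays open.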